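Cytotoxicity notes: benzyloxy to (oxan-2-yl)oxy swap

The source may hold more compounds than are shown below. What is called first, only, known or untested is meant among the compounds shown, and "the series" means these compounds.

Measured compounds:
- compound 1, `COc1cc(/C=C/c2cc(SC)nc(N)n2)cc(OC)c1OC`: in an ADME assay on Vero cells (Chlorocebus sabaeus) for cytotoxicity, read by MTT assay, with a stated time of 72 h (a lower number here means that less compound is tolerated, a higher number that more compound is tolerated), compound 1 gives "not determined" (no result reported)
- compound 2, `CSc1cc(/C=C/c2ccc(OCc3ccccc3)cc2)nc(N)n1`: 376000 nM

Compound 1 carries a trimethoxyphenyl-type vinyl group on the shared core; in this assay no number was reported for compound 1, so it gives no anchor for the series. Compound 2 therefore holds the only numeric entry here; in this assay compound 2 gives 376000 nM, a concentration far above the usual potency window, that is, the cells tolerate a good deal of compound 2.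

Compound 3, `CSc1cc(/C=C/c2ccc(OC3CCCCO3)cc2)nc(N)n1`, is the next member. It differs from compound 2 in one place: oxan-2-yl in place of benzyl on an oxygen on an aromatic ring. For the measured compounds named here, no step between two measured compounds exists in this set, so nothing in the data shows how such a change moves the read-out of this assay.

Going by the values given here, with only the single value of compound 2 available, the expectation for compound 3 is a step that stays within the scatter of this assay or rises slightly, meaning a 1.1-fold higher number from compound 2 to compound 3 (0.03 log units; within the scatter). On that basis compound 3 is estimated at 400000 nM, with an expected range from 150000 nM to 1000000 nM.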

Compound 3, half-maximal cytotoxic concentration: 122000 nM
The estimate for compound 3 lay 3.3-fold (0.52 log units) above the measured number; measured number outside the range, below it.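

In this assay this position is not silent: oxan-2-yl in place of benzyl on an oxygen on an aromatic ring gives a 3.1-fold lower number from compound 2 to compound 3 (0.49 log units; beyond the scatter), so the group carried on this oxygen can move the read-out, here towards less compound being tolerated. The change replaces a six-membered aromatic ring of carbon only with a six-membered non-aromatic ring with 1 hetero atom, and this single step cannot separate the loss of the aromatic ring from the gain of the ring oxygen. No measurement on the origin of the step is available.

As far as these compounds go, whether the lower number belongs to the oxan-2-yl group alone or would also appear with other groups on this oxygen remains open, as a single step gives no trend for this position. A plain methyl group, a free hydroxyl, a cyclohexyl ring or a chain ending in an amine at this position would show whether ring oxygen, ring aromaticity or simply the group on this oxygen tracks with the tolerated concentration.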